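Formyl for ethyl on the phenyl of compound 3

A few compounds are considered here, and "the series" means these few. Any claim that something is new, unique, unknown or untested is made for them only; others in the source may bear on it.

Compound 1 `Fc1ccc(-c2cn3ccnc3c(-c3ccc4ncn(C5CCCCC5)c4c3)n2)cc1`: 17.6%
Compound 2 `c1cn2cc(-c3ccsc3)nc(-c3ccc4ncn(C5CCCCC5)c4c3)c2n1`: 5.56%
Compound 3 `CCc1ccc(-c2cn3ccnc3c(-c3ccc4ncn(Cc5ccccc5)c4c3)n2)cc1`: 21.8%

In a functional assay on Hs-578T cells (Homo sapiens) for inhibition, read by sulforhodamine B assay, with a stated time of 48 h, tested at 10 uM (a lower number here means less inhibition, a higher number more inhibition at the concentration tested (going by the name of the read-out)), compound 3 gives 21.8%, the highest of the three numbers; compound 1 sits within the scatter of it, while compound 2 lies beyond the scatter below it. Compound 4 `O=Cc1ccc(-c2cn3ccnc3c(-c3ccc4ncn(Cc5ccccc5)c4c3)n2)cc1` has not yet been measured. It differs from compound 3 by formyl in place of ethyl on an aromatic carbon, on an aromatic carbon of a six-membered aromatic ring of carbon only. Among the compounds with values here, the only measured step, a number 12 percentage points lower from compound 1 to compound 2 (beyond the scatter), replaces the whole aryl group rather than a substituent on it, so it bears only loosely here. Within the data shown here, with no step of the same kind to draw on, compound 4 is expected to stay close to compound 3, with a number 3.8 percentage points lower from compound 3 to compound 4 (within the scatter) expected to stay within the scatter. Compound 4 is estimated at 18%, in the range 5% to 32%.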

Compound 4, a percentage reported as inhibition, at one concentration (the size of the read-out at that concentration, not a potency): 45.5%
Estimate against measurement, compound 4: 27.5 percentage points below; the measured number lies above the stated range.
By their numbers in this assay, from the lowest: compound 2; then compounds 1 and 3 (each within the scatter of the next); then compound 4.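

In this assay the change from 4-ethylphenyl to 4-formylphenyl gives a number 23.7 percentage points higher from compound 3 to compound 4 (beyond the scatter) and so shows that a small substituent para to a large group can move this read-out on its own, whereas the earlier step, a number 12 percentage points lower from compound 1 to compound 2 (beyond the scatter) and replaced the whole aryl group. The formyl brings a hydrogen-bond acceptor and a double bond outside aromatic rings, but no evidence connects the rise to either feature. Whether the rise is specific to formyl remains open, since a carboxylic acid, a hydroxymethyl or an aminomethyl group at this position is not among the compounds shown. Also open, as far as these compounds go, is whether formyl has the same effect with cyclohexyl in place of benzyl on the core.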